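Swapping 2-methylphenyl for 4-iodophenyl on the shared core

A few compounds are considered here, and "the series" means these few. Any claim that something is new, unique, unknown or untested is made for them only; others in the source may bear on it.

Four compounds share one core, and three of them have been measured in an ADME assay on BJ cells (Homo sapiens) for cytotoxicity, with a stated time of 72 h; a higher number here means that more compound is needed for the effect, a lower number that less compound is needed. Compound 1 (`CCc1ccc(-c2nc3c(c(C)nn3-c3ccccc3)c(-c3ccccc3C(=O)OC)c2C#N)cc1`) gives > 20000 nM, which is a limit of the assay and not a number. Compound 2 (`C#Cc1ccccc1-c1c(C#N)c(-c2ccc(CC)cc2)nc2c1c(C)nn2-c1ccccc1`) gives > 20000 nM, again a limit. Going by the values given here, compound 3 (`Cc1ccccc1-c1nc2c(c(C)nn2-c2ccccc2)c(-c2ccccc2O)c1C#N`) gives 21000 nM, the only true number among the three.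

Compound 4 (`Cc1nn(-c2ccccc2)c2nc(-c3ccc(I)cc3)c(C#N)c(-c3ccccc3O)c12`) departs from compound 3 in one place: 4-iodophenyl in place of 2-methylphenyl on an aromatic carbon. The new group stands on the same aromatic carbon, next to the ring nitrogen and ortho to the cyano group.

Among the compounds with values here, the only measured step offers no size to carry over. It is a step that the two limits leave unreadable from compound 1 to compound 2, and it concerns ethynyl in place of methoxycarbonyl, not the group exchanged here. What remains as a guide is the limit of > 20000 nM in this assay, at which 2 of the 3 values shown sit. Within the data shown here, with no measured step at this position, no clear shift in either direction is expected, though a slight move towards less compound being needed is allowed for. The estimated step, a 1.2-fold lower number from compound 3 to compound 4 (0.07 log units; within the scatter), is expected to stay within the usual scatter. For compound 4 the expected value is 18000 nM, with an estimated range of 8000 nM to 40000 nM.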

Compound 4, half-maximal effective concentration: 19000 nM
Compound 4: the middle estimate sits 1.1-fold (0.02 log units) below what was measured, within the range that was stated.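

In this assay, the exchange of 2-methylphenyl for 4-iodophenyl, on the aromatic carbon next to the ring nitrogen and ortho to a cyano group, amounts to a 1.1-fold lower number from compound 3 to compound 4 (0.04 log units; within the scatter). Going by these compounds alone, the earlier compounds offered no readable step, so this is the first size available on the shared core, and it shows that compound 3 and compound 4 cannot be told apart in this assay, even though the two groups differ both in the atom they carry and in where that atom stands on the phenyl ring. The numbers for these two compounds also lie close to a mark that is a limit of the assay and not a number: the limit of > 20000 nM in this assay, at which 2 of the 4 values shown sit.

The single step joins two alterations, the loss of the methyl group and the arrival of the iodine, so the compounds shown cannot say what either would do alone, as they include neither an unsubstituted phenyl nor a 4-methylphenyl partner to compound 3. They also leave open whether this position would give the same reading with an amine or a carboxylic acid on that phenyl ring, or with a longer alkyl chain in its place.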